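A few compounds are considered here, and "the series" means these few. Any claim that something is new, unique, unknown or untested is made for them only; others in the source may bear on it.

Working notes on the series. Three acids of one shared core have been run in an in vitro functional assay on cells for agonist activity at Bombesin receptor subtype-3 (Homo sapiens), read by luminescence and calcium flux; a lower number here means that less compound is needed, a higher number that more compound is needed for the effect. Compound 1 `O=C(O)c1ccccc1-c1ccc(CCc2ncc(CC3CCC3)[nH]2)cc1` gives 588 nM. Compound 2 `O=C(O)c1ccccc1-c1ccc(CCc2ncc(CC3CCOCC3)[nH]2)cc1` gives 338 nM. Compound 3 `O=C(O)c1ccccc1-c1ccc(CCc2ncc(CCC3CCCCC3)[nH]2)cc1` gives 642 nM, the highest of the three numbers, though its distances to the others are small: a 1.1-fold higher number from compound 1 to compound 3 (0.04 log units; within the scatter) and a 1.9-fold higher number from compound 2 to compound 3 (0.28 log units; within the scatter). Compound 4 `O=C(O)c1ccccc1-c1ccc(CCc2ncc(CC3CC3)[nH]2)cc1` is not yet measured; it differs from compound 3 in one place: cyclopropyl in place of cyclohexylmethyl on a saturated chain carbon bound to an aromatic carbon. The measured steps that bear on this change are the ones that swap the group on the same saturated chain carbon: a 1.7-fold lower number from compound 1 to compound 2 (0.24 log units; within the scatter), a 1.1-fold higher number from compound 1 to compound 3 (0.04 log units; within the scatter) and a 1.9-fold higher number from compound 2 to compound 3 (0.28 log units; within the scatter), every one of them within the scatter. Cyclobutyl, oxan-4-yl and cyclohexylmethyl all land in the same band, so exchanging cyclohexylmethyl for cyclopropyl is expected to yield a step of about a 1.1-fold lower number from compound 3 to compound 4 (0.03 log units; within the scatter), nothing beyond the scatter in either direction. Compound 4 is therefore estimated at 600 nM, with a range from 250 nM to 1400 nM.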

Compound 4, half-maximal effective concentration: 1000 nM
Compound 4: the middle estimate sits 1.7-fold (0.22 log units) below what was measured; low and high end bracket the measured number.
By their numbers in this assay, from the lowest: compounds 2, 1, 3 and 4 (each within the scatter of the next, the first and the last beyond it).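

Among these compounds, at this saturated chain carbon bound to an aromatic carbon, cyclopropyl in place of oxan-4-yl gives the first step in this assay to leave the scatter, a modest one: a 3.0-fold higher number from compound 2 to compound 4 (0.47 log units; beyond the scatter). Cyclopropyl stays within the scatter of the other two groups, with a 1.6-fold higher number from compound 3 to compound 4 (0.19 log units; within the scatter) and a 1.7-fold higher number from compound 1 to compound 4 (0.23 log units; within the scatter), so among these four groups only this one pair separates. The data shown offer no explanation for that gap.

Still open, on these data alone, is whether the ring oxygen of oxan-4-yl matters at all, since this step also changes ring size, and whether piperidin-4-yl would fall with oxan-4-yl. Also open, as far as these compounds go, is how an open chain such as isobutyl compares with these rings on the same carbon.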